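Swapping Chloro for Methoxy at the Same Ring Position

The source may hold more compounds than are shown below. What is called first, only, known or untested is meant among the compounds shown, and "the series" means these compounds.

Of the compounds shown here, two have been tested so far in a functional assay on the whole organism (strain Wistar) for inhibition, with Rattus norvegicus as the target, with stated times of 30 min and 2 h, at a dose of 20 mg/kg by the oral route; a higher number here means more inhibition at the dose given (going by the name of the read-out), a lower number less inhibition. Compound 1 `Cc1ccc(C(=O)CCc2nnc(-c3ccccc3)o2)cc1` gives 33.3%, and compound 2 `Cc1ccc(C(=O)CCc2nnc(-c3ccc(Cl)cc3)o2)cc1` gives 62.7%. Going by the values given here, compound 2 therefore stands highest of the two numbers, and the only measured step, a number 29.4 percentage points higher from compound 1 to compound 2 (beyond the scatter), shows that adding a chloro group at this place raises the read-out beyond the scatter. Compound 3 `COc1ccc(-c2nnc(CCC(=O)c3ccc(C)cc3)o2)cc1` is the next compound to be measured; it differs from compound 2 by methoxy in place of chloro on an aromatic carbon. Among the compounds with values here, no measured step compares methoxy with chloro, so the only guide is that a group at this place, rather than hydrogen, went with the higher value of compound 2. Compound 3 is therefore expected to keep a substituted ring but may not match compound 2 exactly, and the estimated step is a number 12.7 percentage points lower from compound 2 to compound 3 (beyond the scatter). The estimate for compound 3 in this assay is 50%, with a range from 30% to 70%.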

Compound 3, a percentage reported as inhibition, in the whole organism at one dose (the size of the read-out at that dose, not a potency): 69.3%
The estimate for compound 3 lay 19.3 percentage points below the measured number; low and high end bracket the measured number.
By their numbers in this assay, from the lowest: compound 1; then compounds 2 and 3 (each within the scatter of the next).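

In this assay the swap from chloro to methoxy gives a number 6.6 percentage points higher from compound 2 to compound 3 (within the scatter) and so does not separate these two groups at this place. Set against the unsubstituted ring, methoxy gives a number 36 percentage points higher from compound 1 to compound 3 (beyond the scatter) and joins chloro in clearly exceeding the hydrogen compound. The rise seen earlier is therefore not unique to chloro: on this aromatic carbon, para to a large group, two different groups, one of a single heavy atom and one of two, both go with a higher read-out than hydrogen.

From the compounds shown here alone, whether that holds for an amine, a carboxylic acid or a longer chain at this same place stays open. Nothing measured here bears on why chloro and methoxy give such similar numbers.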